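Methoxy addition from compound 2 to compound 4

This account rests on a few compounds, and the source may have more. Where it says the series, first, only, none or still open, it means among the compounds named here.

In a functional assay on HeLa cells (Homo sapiens) for inhibition, read by MTT assay, with a stated time of 72 h (a lower number here means a stronger inhibitor, a higher number a weaker inhibitor), compound 2 `COc1ccc(/C=C/C(=O)c2c(O)cc(O)cc2OC)cc1OC` gives 49500 nM. Compound 3 `COc1cc(OC)c(OC)cc1/C=C/C(=O)c1c(O)cc(O)cc1OC` gives 37800 nM, within the scatter of compound 2. Compound 1 `COc1cc(/C=C/C(=O)c2c(OC)cc(O)c(CC=C(C)C)c2O)cc(OC)c1OC` is reported only as a limit, > 50000 nM, as noted in the limit of > 50000 nM in this assay, at which 1 of the 3 values shown sits. Compound 4 `COc1cc(/C=C/C(=O)c2c(O)cc(O)cc2OC)cc(OC)c1OC` differs from compound 2 by methoxy in place of hydrogen on an aromatic carbon, a methoxy in place of hydrogen on an aromatic carbon. Within the data shown here, the one measured step of this type is a 1.3-fold lower number from compound 2 to compound 3 (0.12 log units; within the scatter), so no step beyond the scatter is expected in this assay. The estimated step is a 1.3-fold lower number from compound 2 to compound 4 (0.11 log units; within the scatter). The expected value for compound 4 is 38000 nM, with an estimated range of 18000 nM to 50000 nM.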

Compound 4, half-maximal inhibitory concentration: 18900 nM
Beside the measured number, compound 4's estimate is 2.0-fold (0.30 log units) above it, and the stated range covers the measured number.
By their numbers in this assay, from the lowest: compounds 4, 3 and 2 (each within the scatter of the next, the first and the last beyond it). At a limit, above all of these: compound 1.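

In this assay, methoxy in place of hydrogen on the aromatic carbon ortho to a methoxy group gives a 2.6-fold lower number from compound 2 to compound 4 (0.42 log units; beyond the scatter), whereas the same replacement in compound 3 gave a 1.3-fold lower number from compound 2 to compound 3 (0.12 log units; within the scatter). Compound 3 and compound 4 nevertheless lie within the scatter of each other, so the placement of the methoxy is not resolved. Hydrogen in place of 3-methylbut-2-en-1-yl gives an at least 2.6-fold lower number from compound 1 to compound 4 (0.42 log units; beyond the scatter), which is only a bound, since the value of compound 1 is a limit: the limit of > 50000 nM in this assay, at which 1 of the 4 values shown sits.

Going by these compounds, it remains open whether an ethoxy group or an amine at this position would match the methoxy step.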